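The source may report more compounds than this note shows. Statements on the series, on what has been measured and on what is new or still open speak of the compounds shown alone.

Measured so far in a functional assay on HaCaT cells (Homo sapiens) for inhibition, read by sulforhodamine B assay, with a stated time of 48 h (a higher number here means a weaker inhibitor of growth, a lower number a stronger inhibitor of growth), are these compounds:
- compound 1 (`CC1(/C=C/c2ccc(F)cc2)C=CC(=O)O1`) gives 47500 nM
- compound 2 (`COc1ccc(/C=C/C2(C)C=CC(=O)O2)c(OC)c1`) gives 53600 nM
- compound 3 (`COc1ccc(/C=C/C2(C)C=CC(=O)O2)cc1OC`) gives 838000 nM

Compound 3 has the highest number of the three, and its gap to each of the other two lies beyond the scatter, which makes it the weakest growth inhibitor of this small set. Compounds 1 and 2 lie within the scatter of each other.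

Compound 4 (`COc1ccc(/C=C/C2(C)C=CC(=O)O2)cc1`) has not yet been measured. It differs from compound 3 in one place, with hydrogen in place of methoxy on an aromatic carbon. Among the measured compounds shown here, no measured pair differing in a single place is available, so the expectation rests on the values alone and remains loose. Compound 3 stands apart at 838000 nM while compound 1 gives 47500 nM and compound 2 gives 53600 nM in this assay and so compound 4 is expected to fall nearer these two. The expected change is a 10-fold lower number from compound 3 to compound 4 (1.02 log units; beyond the scatter) toward a lower number and beyond the scatter. For compound 4 the estimate is 80000 nM with 28000 nM to 350000 nM as its expected range.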

Compound 4, concentration for total growth inhibition: 316000 nM
Compound 4: the middle estimate sits 4.0-fold (0.60 log units) below what was measured; the range from low to high includes it.
By their numbers in this assay, from the lowest: compounds 1 and 2 (each within the scatter of the next); then compound 4; then compound 3.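

In this assay, hydrogen in place of methoxy on an aromatic carbon ortho to a methoxy group and meta to a group of 9 heavy atoms gives a 2.7-fold lower number from compound 3 to compound 4 (0.42 log units; beyond the scatter), so the methoxy at this position goes with weaker growth inhibition, though the step is modest. The same exchange of hydrogen for methoxy on a different aromatic carbon runs the opposite way, with a 5.9-fold higher number from compound 2 to compound 4 (0.77 log units; beyond the scatter), which shows that the direction of this change depends on where on the ring the methoxy stands, at least in this pair of steps. Methoxy in place of fluoro on an aromatic carbon also goes with weaker growth inhibition, giving a 6.7-fold higher number from compound 1 to compound 4 (0.82 log units; beyond the scatter), so the single methoxy of compound 4 does not match the fluoro of compound 1 in this assay.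

Nothing available here accounts for the opposite directions of the two methoxy steps. Going by these compounds, it remains open whether a hydroxyl group, an amine or a longer alkoxy chain on the aromatic carbon that changed between compound 3 and compound 4 would track with the methoxy or with the hydrogen.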